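Ethoxy to methoxy on a core without measured cytotoxicity

The compounds below may be only part of what the source reports. "The series", "measured", "known", "first", "only" and "open" are said of these compounds alone.

Three measured compounds share one core, and none of them gives a number in a functional assay on A549 cells (Homo sapiens) for cytotoxicity, read by MTT assay, with a stated time of 48 h; a lower number here means a stronger inhibitor, a higher number a weaker inhibitor. Compound 1 `CCOC(=O)[C@@H]1C[C@@]23CN(C)C[C@@H](CCC4=C2[C@@H]1CC4=O)C31CC[C@](CC)(OC)OC1` reaches only the limit of the assay in this assay, at > 40000 nM. Compound 3 `CC[C@]1(OC)CCC2(CO1)[C@@H]1CCC3=C4[C@H](CC3=O)[C@H](C(=O)OC)C[C@@]42CN(C)C1` likewise sits at the limit of the assay in this assay, at > 40000 nM. For the measured compounds named here, the single one-place step between them, a step that the two limits leave unreadable from compound 1 to compound 3, therefore has no readable size. Compound 2 `CCO[C@@]1(CC)CCC2(CO1)[C@@H]1CCC3=C4[C@@H](CC3=O)[C@H](C(=O)OC)C[C@@]42CN(C)C1` also stands at the limit of the assay in this assay, with > 40000 nM. Because the limit of > 40000 nM in this assay, at which 3 of the 3 values shown sit, holds for every measured compound, the numbers shown do not separate any of them.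

Compound 4 `CC[C@]1(OC)CCC2(CO1)[C@@H]1CCC3=C4[C@@H](CC3=O)[C@H](C(=O)OC)C[C@@]42CN(C)C1` is compound 2 with one change: hydrogen in place of methyl on a saturated chain carbon bound to an oxygen on a saturated carbon. Going by the values given here, no measured pair carries exactly this change; the only measured step of a related kind, from compound 1 to compound 3, has no readable size, and neither of its two compounds gives a number in this assay. On that footing, the step expected from this change is a step that the limit leaves unreadable from compound 2 to compound 4, no larger than the usual scatter, with the outcome most likely being another limit rather than a number. Compound 4 is accordingly estimated at 60000 nM, within a range from 40000 nM to 200000 nM.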

Compound 4, half-maximal inhibitory concentration: > 40000 nM
Compound 4: no number, only a limit (the forecaster's own chance of this, stated with the estimate: 85%); the middle value is on the limit's open side.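

In this assay compound 4 gives > 40000 nM, a limit and not a number. The steps joining compound 4 to compound 2 and to compound 3 cannot be read, because no number stands at either end: the limit of > 40000 nM in this assay, at which 4 of the 4 values shown sit. The compounds shown leave open what size, if any, these changes have in this assay.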